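Working notes: exchanging the group on the carbonyl carbon

The source may report more compounds than this note shows. Statements on the series, on what has been measured and on what is new or still open speak of the compounds shown alone.

Measured in a functional assay on Shh Light II cells (Mus musculus) for inhibition, read by a luciferase reporter; a higher number here means a weaker inhibitor, a lower number a stronger inhibitor:
- compound 1 `O=C(NC1CCS(=O)(=O)CC1)N1CCC(c2nc(-c3ccc4ccccc4n3)no2)CC1`: 360 nM
- compound 2 `CC(=O)N1CCC(NC(=O)N2CCC(c3nc(-c4ccc5ccccc5n4)no3)CC2)CC1`: 500 nM
- compound 3 `COc1ccccc1N(C)C(=O)N1CCC(c2nc(-c3ccc4ccccc4n3)no2)CC1`: 3100 nM

Compound 3 has the highest number of the three in this assay. Compounds 1 and 2 lie within the scatter of each other, with a 1.4-fold higher number from compound 1 to compound 2 (0.14 log units; within the scatter).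

The next compound is compound 4 `O=C(OCc1ccccc1)N1CCC(c2nc(-c3ccc4ccccc4n3)no2)CC1`, which has benzyloxy in place of (2-methoxyphenyl)(methyl)amino on a carbonyl carbon. Both groups hold one six-membered aromatic ring of carbon only.

Two measured steps change the group at this place, and both are modest: an 8.6-fold higher number from compound 1 to compound 3 (0.94 log units; beyond the scatter) and a 6.2-fold higher number from compound 2 to compound 3 (0.79 log units; beyond the scatter). They show that this place can move the number beyond the scatter, but both start from groups without an aromatic ring. Among the measured compounds shown here, no measured compound carries benzyloxy, and no measured step exchanges two groups with an aromatic ring. Compound 4 is therefore expected to stay near compound 3 at 3100 nM, with no step beyond the scatter expected, although a somewhat lower number is possible.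

The expected change is a 1.6-fold lower number from compound 3 to compound 4 (0.19 log units; within the scatter).

For compound 4 the estimated value is 2000 nM, with an expected range of 500 nM to 7000 nM.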

Compound 4, half-maximal inhibitory concentration: > 2500 nM
Compound 4 gave a limit, no number (the forecaster's own chance of this, stated with the estimate: 5%); middle value at least 1.2-fold (0.09 log units) away from the limit.
By their numbers in this assay, from the lowest: compounds 1 and 2 (each within the scatter of the next); then compound 3.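

In this assay compound 4 gives > 2500 nM, which is a limit of the assay and not a number: the limit of > 2500 nM in this assay, at which 1 of the 4 values shown sits.
Even so, the limit places benzyloxy, a second group with one six-membered aromatic ring of carbon only, clearly apart from the two groups without an aromatic ring, with an at least 5.0-fold higher number from compound 2 to compound 4 (0.69 log units; beyond the scatter) and an at least 6.9-fold higher number from compound 1 to compound 4 (0.84 log units; beyond the scatter).
Among the four compounds shown, the two with an aromatic ring in this group therefore both sit beyond the scatter from compounds 1 and 2, while the step between compound 3 and compound 4 cannot be read.

The compounds shown leave open whether the aromatic ring itself goes with the higher numbers, since compounds 3 and 4 also both lack the amide hydrogen that compounds 1 and 2 carry on this carbonyl carbon. A benzylamino group in this place would keep the ring and the amide hydrogen together, and a cyclohexyloxy group would lack both, so the pair could separate the two features.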